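Swapping a pyrazole for a propyl chain: cell toxicity

The source may hold more compounds than are shown below. What is called first, only, known or untested is meant among the compounds shown, and "the series" means these compounds.

The study looks at cell toxicity in a toxicity assay on THP-1 cells (Homo sapiens) for inhibition; on this read-out higher numbers stand for lower toxicity in this test and lower numbers for higher toxicity in this test. Compound 1 has the structure `COc1ccc(-c2cnc(NC(=O)c3ccn[nH]3)n2C)cc1`. In this assay compound 1 gives only a limit, > 100000 nM, and not a number. Compound 2 has the structure `Cc1ccccc1C(=O)Nc1ncc(-c2ccccc2)n1C`. In this assay compound 2 likewise gives only a limit, > 100000 nM. Both measured values coincide with the limit of > 100000 nM in this assay, at which 2 of the 2 values shown sit, so compound 1 stands exactly where the other measured compound stands, with no toxicity seen up to that limit. Among the measured compounds shown here, no pair of measured compounds differs in one place, so no step between them can be counted.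

Compound 3, with the structure `CCCC(=O)Nc1ncc(-c2ccc(OC)cc2)n1C`, is not yet measured. It differs from compound 1 by propyl in place of 1H-pyrazol-5-yl on a carbonyl carbon. The expected outcome is a step of no size beyond the scatter, a number no higher from compound 1 to compound 3 (the limit leaves the size open). Compound 3 is therefore estimated at 100000 nM, with a range from 50000 nM to 200000 nM, and most likely again reported as a limit.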

Compound 3, half-maximal cytotoxic concentration: > 100000 nM
Compound 3: only a limit was reported; the forecaster's own chance of this, stated with the estimate: 80%; the middle value lies on the limit itself.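

No step from compound 1 to compound 3 can be read in this assay, since each compound gives only a limit and not a number: the limit of > 100000 nM in this assay, at which 3 of the 3 values shown sit.

The compounds shown leave open whether propyl in place of 1H-pyrazol-5-yl changes cell toxicity at all, and in which direction.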